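The source may report more compounds than this note shows. Statements on the series, on what has been measured and on what is new or still open speak of the compounds shown alone.

Measured in an ADME assay on MDBK cells (Bos taurus) for cytotoxicity; a higher number here means that more compound is tolerated, a lower number that less compound is tolerated:
Compound 1 `N#Cc1ccc(Cn2ccc3nc(-c4ccccc4)nc-3c2)cc1`: > 100000 nM
Compound 2 `c1ccc(-c2nc3cc[nH]cc-3n2)cc1`: > 100000 nM

Compound 2 gives > 100000 nM, which is a limit of the assay and not a number. Compound 1 gives > 100000 nM, also a limit. Compound 2 therefore stands at the limit of > 100000 nM in this assay, at which 2 of the 2 values shown sit, and no number is available for either compound.

For the measured compounds named here, compound 3 `CC(C)CCn1ccc2nc(-c3ccccc3)nc-2c1` has isopentyl in place of hydrogen on an aromatic nitrogen, the one step to follow here: isopentyl in place of hydrogen on an aromatic nitrogen. Going by the values given here, no measured step is available to size this change in this assay. With compound 1 at > 100000 nM, the expectation is that tolerance stays near the limit, with at most a modest move towards less compound tolerated. The expected step is an at least 1.2-fold lower number from compound 2 to compound 3 (0.09 log units; that floor lies within the scatter). For compound 3 the estimated value is 80000 nM. The expected range for compound 3 is 30000 nM to 100000 nM.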

Compound 3, half-maximal cytotoxic concentration: > 100000 nM
Compound 3 ended at the assay's limit (the forecaster's own chance of this, stated with the estimate: 65%); middle value at least 1.2-fold (0.09 log units) away from the limit.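

No step can be read from compound 2 or compound 1 to compound 3 in this assay, as all three compounds sit at the same limit: the limit of > 100000 nM in this assay, at which 3 of the 3 values shown sit. The compounds shown leave open at what concentration any of them becomes cytotoxic, and whether isopentyl in place of hydrogen shifts tolerance at all.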